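Removing one carbon from a saturated chain

The compounds below may be only part of what the source reports. "The series", "measured", "known", "first", "only" and "open" are said of these compounds alone.

Among the measured compounds shown here, in a functional assay on HEL cells (Homo sapiens) (a lower number here means that less compound is tolerated, a higher number that more compound is tolerated), compound 2 `CCCCCCCc1cc2cn(COCCO)c(=O)nc2o1` gives 140000 nM, the only actual number so far. Compound 1 `CCCCCCC#Cc1cc2cn(COCCO)c(=O)nc2o1` gives > 50000 nM, which is a limit of the assay and not a number. Compound 3 `CCCCCCc1cc2cn(COCCO)c(=O)nc2o1` is compound 2 with a shorter chain: hydrogen in place of methyl on a saturated chain carbon, six bonds along the chain from an aromatic carbon, with hydrogen in place of methyl on a saturated chain carbon. For the measured compounds named here, no measured pair shows what such a change does, so in this assay no step beyond the usual scatter is expected, in either direction. The expected step is no change at the digits printed from compound 2 to compound 3 (within the scatter). For compound 3 the estimated value is 140000 nM, with an expected range of 70000 nM to 280000 nM.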

Compound 3, half-maximal cytotoxic concentration: > 200000 nM
Compound 3 was reported as a limit; the forecaster's own chance of this, stated with the estimate: 45%; at least 1.4-fold (0.15 log units) between middle value and limit.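

Among the compounds shown here, for the first time, a change at this place has a reading: in this assay, hydrogen in place of methyl on a saturated chain carbon, six bonds along the chain from an aromatic carbon, gives an at least 1.4-fold higher number from compound 2 to compound 3 (0.15 log units; that floor lies within the scatter). Compound 3 sits at a limit of the assay, so this step has a floor but no upper end: the limit of > 200000 nM in this assay, at which 1 of the 3 values shown sits. Nothing here suggests that the shorter chain is less tolerated.

As far as these compounds go, the actual number for compound 3 remains open. So does the effect of a butyl chain, a longer chain or a terminal amine.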